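Moving the ring attachment from compound 2 to compound 4

This account rests on a few compounds, and the source may have more. Where it says the series, first, only, none or still open, it means among the compounds named here.

compound 1 `O=C(O)c1cc(-n2cccc2)ccc1O`: 50 mg/kg
compound 2 `O=C(O)c1ccc(-c2cscn2)cc1O`: 70 mg/kg
compound 3 `O=C(O)c1cc(-c2ncccn2)ccc1O`: 100 mg/kg

These three compounds were tested in a functional assay on the whole organism for inhibition, with Rattus norvegicus as the target, read by paw edema (a higher number here means that more compound is needed for the effect, a lower number that less compound is needed), and their numbers lie close together. Compound 2 stands in the middle of the three, and its gaps to compound 1 and to compound 3 are within the usual scatter, so the set shows no clear ranking.

The next compound, compound 4 `O=C(O)c1ccc(-c2nccs2)cc1O`, keeps the core of compound 2 and alters only the attached ring: 1,3-thiazol-2-yl in place of 1,3-thiazol-4-yl on an aromatic carbon. The atoms are the same but joined differently. Going by the values given here, no measured pair here shows a change of this kind, so the data offer no direct guide.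

Compound 1 and compound 3 carry other rings, yet both lie within the scatter of compound 2 (70 mg/kg), so no step beyond the scatter is expected in this assay in either direction. The expected change is a 1.1-fold higher number from compound 2 to compound 4 (0.03 log units; within the scatter) in this estimate. For compound 4 the estimated value is 75 mg/kg, with an expected range from 35 mg/kg to 150 mg/kg.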

Compound 4, dose for half-maximal effect: 110 mg/kg
For compound 4 the middle estimate is 1.5-fold (0.17 log units) below the measured one; the range from low to high includes it.
By their numbers in this assay, from the lowest: compounds 1, 2, 3 and 4 (each within the scatter of the next, the first and the last beyond it).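

In this assay, replacing 1,3-thiazol-4-yl with 1,3-thiazol-2-yl, on the aromatic carbon para to the carboxy group and meta to the hydroxy group, gives a 1.6-fold higher number from compound 2 to compound 4 (0.20 log units; within the scatter), the only step shown between compounds that differ in one place. At this position, then, changing how the thiazole ring is attached, with the same atoms in the ring, produces no clear difference in the dose needed. No other measurement here bears on this result.

The compounds shown leave open whether a different kind of group at this place, such as an amine, a carboxylic acid or a longer alkyl chain, would shift the number beyond the scatter. They also leave open whether the same change in attachment would stay within the scatter at another position on the shared core.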